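The source may report more compounds than this note shows. Statements on the series, on what has been measured and on what is new or still open speak of the compounds shown alone.

In a functional assay on K562 cells (Homo sapiens) for antiproliferative activity, with a stated time of 72 h (a lower number here means a stronger inhibitor, a higher number a weaker inhibitor), compound 2 (`Nc1ncnn2c([C@@H]3O[C@H](CO)[C@@H](O)[C@H]3O)cc(C#Cc3cccs3)c12`) gives > 100000 nM, which is a limit of the assay and not a number. Compound 2 thus stands at the limit of > 100000 nM in this assay, at which 1 of the 2 values shown sits. Among the measured compounds shown here, compound 1 (`Nc1ncnn2c([C@@H]3O[C@H](CO)[C@@H](O)[C@H]3O)cc(C#CC3CC3)c12`) gives 40 nM, and the one measured step, an at least 2500-fold higher number from compound 1 to compound 2 (3.39 log units; beyond the scatter), is large. Compound 3 (`Cc1ccccc1-c1cc([C@@H]2O[C@H](CO)[C@@H](O)[C@H]2O)n2ncnc(N)c12`) brings (2-methylphenyl in place of 2-(thiophen-2-yl)ethynyl on an aromatic carbon), with 2-methylphenyl in place of 2-(thiophen-2-yl)ethynyl on an aromatic carbon. An aromatic end group on compound 2 already gave an at least 2500-fold higher number from compound 1 to compound 2 (3.39 log units; beyond the scatter), so only modest recovery is expected. The expected change in this assay is an at least 5.0-fold lower number from compound 2 to compound 3 (0.69 log units; beyond the scatter), towards a lower number. Compound 3 is estimated at 20000 nM, with an expected range of 2000 nM to 100000 nM.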

Compound 3, half-maximal inhibitory concentration: > 100000 nM
Compound 3 was reported as a limit (the forecaster's own chance of this, stated with the estimate: 50%); middle value at least 5.0-fold (0.69 log units) away from the limit.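

Replacing the triple bond and its end group with 2-methylphenyl does not restore the activity of compound 1 in this assay, with an at least 2500-fold higher number from compound 1 to compound 3 (3.39 log units; beyond the scatter). The loss at this aromatic carbon is therefore not specific to 2-(thiophen-2-yl)ethynyl, and it also occurs in a compound without a triple bond. Compound 2 and compound 3 both give a limit of the assay, so the step between them cannot be read: the limit of > 100000 nM in this assay, at which 2 of the 3 values shown sit.

Open, as far as these compounds go, is how narrow the tolerance around 2-cyclopropylethynyl is. A triple bond ending in a longer alkyl chain or in an amine could show whether any end group other than cyclopropyl keeps the activity of compound 1.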